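Swapping ethyl for chloro on the para position of compound 1

The source may report more compounds than this note shows. Statements on the series, on what has been measured and on what is new or still open speak of the compounds shown alone.

Measured compounds:
compound 1 `C=C(Br)C(=O)Nc1cccc(-c2cn3nc(-c4ccc(CC)cc4)sc3n2)c1` with 2200 nM
compound 2 `C=C(Br)C(=O)Nc1cccc(-c2cn3c(-c4ccc(OC)cc4)csc3n2)c1` with 200 nM

Both compounds carry the same bromoacrylamide arm and were tested in a functional assay on L1210 cells (Mus musculus) for inhibition, read by cell counting, with a stated time of 2 days; on this read-out lower numbers stand for stronger inhibition and higher numbers for weaker inhibition. Compound 1 gives the higher of the two numbers, and compound 2 the lower one; that gap lies beyond the scatter, but the two compounds differ in several places at once, so no single change can be tied to it.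

Compound 3 `C=C(Br)C(=O)Nc1cccc(-c2cn3nc(-c4ccc(Cl)cc4)sc3n2)c1` has not been measured yet. It differs from compound 1 in one place: chloro in place of ethyl on an aromatic carbon. For the measured compounds named here, no measured pair shows this exact change, so its effect on this assay cannot be read from the data.

With nothing to anchor it, the expected step from compound 1 to compound 3 is small, a 1.5-fold lower number from compound 1 to compound 3 (0.17 log units; within the scatter), leaning toward a slightly lower number but within the scatter. Compound 3 is therefore estimated at 1500 nM, with a range from 400 nM to 5000 nM.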

Compound 3, half-maximal inhibitory concentration: 1400 nM
For compound 3 the middle estimate is 1.1-fold (0.03 log units) above the measured one; the range from low to high includes it.
By their numbers in this assay, from the lowest: compound 2; then compounds 3 and 1 (each within the scatter of the next).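

In this assay, for the compounds shown here, chloro in place of ethyl gives a 1.6-fold lower number from compound 1 to compound 3 (0.20 log units; within the scatter), the first reading of a single change at this position on the aromatic ring, para to a large group. The two compounds cannot be told apart here, even though ethyl has two carbons and chloro is a single chlorine, and neither group has hydrogen-bond donors or acceptors. No available data offer an explanation for this result.

All that can be said so far is that these two groups give numbers within the scatter of each other, so the reach of this finding remains unclear. As far as these compounds go, whether an amine, a carboxylic acid or a longer chain in the same place would move the number beyond the scatter remains open, as does whether this swap would behave the same way on another core.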